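The source may hold more compounds than are shown below. What is called first, only, known or untested is meant among the compounds shown, and "the series" means these compounds.

In a functional assay on BT-474 cells (Homo sapiens) for antiproliferative activity, read by sulforhodamine B assay, with a stated time of 4 days (a higher number here means a weaker inhibitor of growth, a lower number a stronger inhibitor of growth), compound 1 `COc1cc(Cl)c(-c2nc(SCC(=O)NC(C)(C)C)nc3[nH]cc(C#N)c23)cc1OC` gives 121 nM and compound 2 `CCOc1cc(-c2nc(SCC(=O)NC(C)C)nc3[nH]cc(C#N)c23)c(Cl)cc1OC` gives 84 nM, two numbers within the usual scatter of each other. Compound 3 `COc1cc(Cl)c(-c2nc(SCC(=O)NC(C)C)nc3[nH]cc(C#N)c23)cc1OC` has not yet been measured. It differs from compound 2 by hydrogen in place of methyl on a saturated chain carbon bound to an oxygen on an aromatic ring, which turns ethoxy into methoxy. For the measured compounds named here, no measured pair shows this change, so no shift beyond the scatter is expected in this assay, in either direction. The expected step is a 1.1-fold higher number from compound 2 to compound 3 (0.03 log units; within the scatter). For compound 3 the estimated value is 90 nM, with an expected range of 40 nM to 200 nM.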

Compound 3, concentration for 50% growth inhibition: 81 nM
Estimate against measurement, compound 3: 1.1-fold (0.05 log units) above; low and high end bracket the measured number.
By their numbers in this assay, from the lowest: compounds 3, 2 and 1 (each within the scatter of the next).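

Ethoxy and methoxy on the aromatic ring cannot be told apart in this assay, with a 1.0-fold lower number from compound 2 to compound 3 (0.02 log units; within the scatter). Hydrogen in place of methyl on a saturated chain carbon bound to an amide-type nitrogen and two saturated chain carbons also stays within the scatter, with a 1.5-fold lower number from compound 1 to compound 3 (0.17 log units; within the scatter). No other information here bears on these results.

The compounds shown leave open what a longer chain, such as butoxy, would do at the oxygen. They also leave open how an amine or a carboxylic acid at the end of that chain would read.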